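From difluoromethoxy to 1,1,2,2-tetrafluoroethoxy

A few compounds are considered here, and "the series" means these few. Any claim that something is new, unique, unknown or untested is made for them only; others in the source may bear on it.

In an ADME assay for pharmacokinetics, at pH 7.4 (on this read-out lower numbers stand for a shorter-lived compound and higher numbers for a longer-lived compound), compound 1 `COc1cnc(C[S+]([O-])c2nc3cc(OC(F)F)ccc3[nH]2)cc1OC` gives > 200 h, which is a limit of the assay and not a number. Among the measured compounds shown here, compound 2 `COc1ccnc(C[S+]([O-])c2nc3cc(OC(F)F)ccc3[nH]2)c1` gives 51 h, the only true number so far. Compound 3 `COc1ccnc(C[S+]([O-])c2nc3cc(OC(F)(F)C(F)F)ccc3[nH]2)c1` changes compound 2 by difluoromethyl in place of hydrogen on a saturated chain carbon bound to two fluorine atoms and an oxygen on an aromatic ring, turning difluoromethoxy into 1,1,2,2-tetrafluoroethoxy. For the measured compounds named here, the one measured step, an at least 3.9-fold lower number from compound 1 to compound 2 (0.59 log units; beyond the scatter), swaps methoxy for hydrogen on an aromatic carbon, a different change, so it sets no size here. The expected step is a 1.1-fold lower number from compound 2 to compound 3 (0.05 log units; within the scatter), with nothing beyond the scatter anticipated. For compound 3 the estimate is 45 h, ranging from 17 h to 120 h.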

Compound 3, half-life: 63 h
Estimate against measurement, compound 3: 1.4-fold (0.15 log units) below; the measured number falls inside the stated range.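

In this assay the step is a 1.2-fold higher number from compound 2 to compound 3 (0.09 log units; within the scatter), so placing difluoromethyl on this saturated chain carbon gives a half-life that cannot be told apart from the one before it. Among the compounds shown here, the earlier step concerned only methoxy and hydrogen on an aromatic carbon, so this is the first reading of the difluoromethoxy end, and 1,1,2,2-tetrafluoroethoxy is tolerated there. Compound 1 alone stands as a limit and not a number: the limit of > 200 h in this assay, at which 1 of the 3 values shown sits.

On these data alone, whether a longer fluorinated chain, an amine or a carboxylic acid on that same carbon would also leave the half-life in place stays open. So does how 1,1,2,2-tetrafluoroethoxy behaves alongside the extra methoxy of compound 1.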